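Swapping the Ring on the Amide Side Chain

The source may report more compounds than this note shows. Statements on the series, on what has been measured and on what is new or still open speak of the compounds shown alone.

Of the compounds shown here, three sharing one core have been measured in an assay on HEK293 cells for agonist activity at transient receptor potential cation channel subfamily M member 8 (Homo sapiens), read by fluorescence and calcium flux, with a stated time of 15 min; a lower number here means that less compound is needed, a higher number that more compound is needed for the effect. Compound 1 `CCN(Cc1cccs1)C(=O)COc1ccc(C)cc1` gives 8 nM, compound 2 `CCN(Cc1ccoc1)C(=O)COc1ccc(C)cc1` gives 136 nM, and compound 3 `CCN(Cc1c[nH]nn1)C(=O)COc1ccc(C)cc1` gives 31100 nM. Compound 3 therefore stands highest of the three, meaning it needs the most material to reach the effect; the step of a 230-fold higher number from compound 2 to compound 3 (2.36 log units; beyond the scatter) and the step of a 3900-fold higher number from compound 1 to compound 3 (3.59 log units; beyond the scatter) both lie far beyond the scatter.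

Compound 4 `CCN(Cc1cncs1)C(=O)COc1ccc(C)cc1` has not yet been measured. Its change from compound 3 is 1,3-thiazol-5-yl in place of 1H-1,2,3-triazol-4-yl on a saturated chain carbon bound to an amide-type nitrogen. Within the data shown here, two measured steps bear on this. Read in reverse, a 3900-fold higher number from compound 1 to compound 3 (3.59 log units; beyond the scatter) shows how much is lost when a sulfur-containing five-membered ring is exchanged for the triazole, and a 230-fold higher number from compound 2 to compound 3 (2.36 log units; beyond the scatter) shows a smaller but still large loss from the furan. The ring entering in compound 4 contains sulfur, as does the ring of compound 1, but it also carries a ring nitrogen, so a large downward step is expected, though probably not all the way back to where compound 1 sits. For compound 4 the expected step is a 78-fold lower number from compound 3 to compound 4 (1.89 log units; beyond the scatter). Compound 4 is thus estimated at 400 nM, with a range from 60 nM to 3000 nM.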

Compound 4, half-maximal effective concentration: 1100 nM
Compound 4: the middle estimate sits 2.8-fold (0.44 log units) below what was measured, and the stated range covers the measured number.
By their numbers in this assay, from the lowest: compound 1; then compound 2; then compound 4; then compound 3.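

The 1,3-thiazol-5-yl ring recovers much of what the 1H-1,2,3-triazol-4-yl ring loses on this saturated chain carbon (a 28-fold lower number from compound 3 to compound 4 (1.45 log units; beyond the scatter)), so the site does not demand one exact ring, yet having sulfur in the ring does not bring back the activity of the thiophen-2-yl compound (a 140-fold higher number from compound 1 to compound 4 (2.14 log units; beyond the scatter)). The sulfur-free furan-3-yl ring also needs less compound than the sulfur-containing thiazole (an 8.1-fold higher number from compound 2 to compound 4 (0.91 log units; beyond the scatter)), which shows that the presence of sulfur alone does not set the order among these four compounds. The step from triazole to thiazole also changes more than one thing at once, since the ring loses its hydrogen-bond donor and exchanges nitrogen atoms for a sulfur atom and a carbon atom, and these four values cannot separate those changes.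

No measurement at hand explains why the rings fall in this order. On these data alone, all four compounds carry a five-membered aromatic ring at this place, so it remains open how a six-membered ring such as phenyl or pyridyl, or an open chain such as butyl, would behave there.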